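Bromo for Methoxy: Expected Whole-Animal Toxicity of Compound 4

The source may hold more compounds than are shown below. What is called first, only, known or untested is meant among the compounds shown, and "the series" means these compounds.

Compound 1 `C=CCNC(=O)/C(C)=C(/C)c1ccc(OC)cc1`: 280 mg/kg
Compound 2 `COc1ccc(/C(C)=C(/C)C(=O)NC2CC2)cc1`: 300 mg/kg
Compound 3 `C#CCNC(=O)/C(C)=C(\C)c1ccc(OC)cc1`: 150 mg/kg

In a toxicity assay on the whole organism (strain Icem-CET (SPF Caw)) for cytotoxicity, with Mus musculus as the target (on this read-out lower numbers stand for an effect already at smaller amounts and higher numbers for an effect only at larger amounts of compound), compound 1 has the second highest of the three numbers. The nearest is compound 2, reached by a 1.1-fold higher number from compound 1 to compound 2 (0.03 log units; within the scatter) through cyclopropyl in place of allyl on an amide-type nitrogen. The furthest is compound 3, whose value 150 mg/kg still lies within the scatter of compound 1.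

Compound 4 `C=CCNC(=O)/C(C)=C(/C)c1ccc(Br)cc1` differs from compound 1 by bromo in place of methoxy on an aromatic carbon. Among the measured compounds shown here, no measured step touches that part of the shared core; the single step known, a 1.1-fold higher number from compound 1 to compound 2 (0.03 log units; within the scatter), changes a different place and stays within the scatter. Nothing in these data therefore points to a shift, and compound 4 is expected to show no change at the digits printed from compound 1 to compound 4 (within the scatter), essentially none beyond the scatter. Compound 4 is estimated at 280 mg/kg, with a range from 140 mg/kg to 560 mg/kg.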

Compound 4, dose for half-maximal effect: 400 mg/kg
The estimate for compound 4 lay 1.4-fold (0.15 log units) below the measured number; the measured number falls inside the stated range.
By their numbers in this assay, from the lowest: compounds 3, 1, 2 and 4 (each within the scatter of the next, the first and the last beyond it).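

In this assay, among the compounds shown here, the earlier compounds varied only the group on the amide-type nitrogen, whereas this is the first reading at the aromatic carbon: bromo in place of methoxy gives a 1.4-fold higher number from compound 1 to compound 4 (0.15 log units; within the scatter). Compound 1 and compound 4 therefore cannot be told apart in this whole-animal test, although a single swap says little about the position as a whole. Nothing available explains why these two groups read alike. Going by these compounds, it remains open how an amine or a carboxylic acid would read at this carbon. On these data alone, it also remains open whether bromo would read the same with the cyclopropyl group of compound 2 on the nitrogen.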